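A few compounds are considered here, and "the series" means these few. Any claim that something is new, unique, unknown or untested is made for them only; others in the source may bear on it.

Among the measured compounds shown here, compound 2 `O=C(Nc1cccc(O)c1)c1cccc(N2C(=O)c3ccccc3C2=O)c1` gives the highest number of the two measured so far in an in vitro functional assay on HEK293-A cells for antagonist activity at metabotropic glutamate receptor 5 (Rattus norvegicus), read by calcium flux (a higher number here means a weaker inhibitor, a lower number a stronger inhibitor), namely 7790 nM. Its nearest neighbour is compound 1 `O=C(Nc1ccccc1O)c1cccc(N2C(=O)c3ccccc3C2=O)c1`, which in this assay gives 77 nM; the move from one to the other, a 3-hydroxyphenyl in place of a 2-hydroxyphenyl on the amide-type nitrogen, is a 100-fold higher number from compound 1 to compound 2 (2.01 log units; beyond the scatter), so the 3-hydroxyphenyl compound is by far the weaker inhibitor of the pair.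

Compound 3 `COc1cc(NC(=O)c2cccc(N3C(=O)c4ccccc4C3=O)c2)cc(OC)c1` has not been measured. It differs from compound 2 in one place: 3,5-dimethoxyphenyl in place of 3-hydroxyphenyl on an amide-type nitrogen. For the measured compounds named here, no measured step covers this kind of change; the only step known, the shift of the hydroxyl from one position of the ring to another, says nothing direct about trading the hydroxyl for two methoxy groups. The weak starting point of compound 2 offers no reason to expect a return toward the number of compound 1, and the step between compound 2 and compound 3 is therefore expected to be a 1.3-fold higher number from compound 2 to compound 3 (0.11 log units; within the scatter), which lies within the scatter. On that basis compound 3 is estimated to give 10000 nM in this assay, with a plausible range from 2000 nM to 50000 nM.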

Compound 3, half-maximal inhibitory concentration: 3580 nM
Compound 3: middle estimate off by 2.8-fold (0.45 log units), on the high side; the measured number falls inside the stated range.
By their numbers in this assay, from the lowest: compound 1; then compound 3; then compound 2.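

On this amide-type nitrogen, a ring with no hydrogen-bond donor is not worse than the 3-hydroxyphenyl ring: in this assay the change to 3,5-dimethoxyphenyl gives a 2.2-fold lower number from compound 2 to compound 3 (0.34 log units; beyond the scatter) and so a modest gain, small but beyond the scatter. The hydroxyl of compound 2 is therefore not needed to hold even its weak level of inhibition, yet the two methoxy groups recover only a little of what separates this series from its best member, as a 46-fold higher number from compound 1 to compound 3 (1.67 log units; beyond the scatter) shows that compound 1 remains far stronger. No measurement at hand explains either step.

Among the compounds shown here, because two methoxy groups enter and the hydroxyl leaves in a single move, the effect of each change cannot be separated here, and a ring carrying only one methoxy group would be needed to do that. As far as these compounds go, it also remains open whether the 2-hydroxyphenyl of compound 1 depends on its hydroxyl specifically, or whether an amine or a methoxy group in that same place would keep the low number.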